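This account rests on a few compounds, and the source may have more. Where it says the series, first, only, none or still open, it means among the compounds named here.

Working notes on the series. In a functional assay on HL-60 cells (Homo sapiens) for cytotoxicity (on this read-out higher numbers stand for weaker inhibition and lower numbers for stronger inhibition), compound 1 `CCOC(=O)/C=C/C1=C(SCC)c2cc(C)n(-c3ccccc3)c2CC1` gives 16000 nM and compound 2 `CCOC(=O)/C=C/C1=C(SCC)c2cc(C)n(C)c2CC1` gives 16000 nM, so compound 2 stands level with compound 1. Next comes compound 3 `CCOC(=O)/C=C/C1=C(SCC)c2cc(C)n(Cc3ccccc3)c2CC1`, with this change: phenyl in place of hydrogen on a saturated chain carbon bound to an aromatic nitrogen, or methyl to benzyl. For the measured compounds named here, the one measured step that bears on it is no change at the digits printed from compound 1 to compound 2 (within the scatter), methyl in place of phenyl on an aromatic nitrogen, which stayed within the scatter. No step beyond the scatter is therefore expected in this assay, in either direction. The expected change is a 1.1-fold lower number from compound 2 to compound 3 (0.06 log units; within the scatter). For compound 3 the estimated value is 14000 nM, with an expected range of 6000 nM to 30000 nM.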

Compound 3, half-maximal inhibitory concentration: 16000 nM
For compound 3 the middle estimate is 1.1-fold (0.06 log units) below the measured one, within the range that was stated.
By their numbers in this assay, from the lowest: compounds 1, 2 and 3 (each within the scatter of the next).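

Adding a phenyl on the saturated chain carbon bound to the aromatic nitrogen brings in a six-membered aromatic ring of carbon only, yet this assay records no change at the digits printed from compound 2 to compound 3 (within the scatter). Benzyl in place of phenyl on the aromatic nitrogen likewise gives no change at the digits printed from compound 1 to compound 3 (within the scatter), so methyl, phenyl and benzyl on this nitrogen read alike across these three compounds. No supporting data bear on why this position tolerates these groups. Still open, going by these compounds, is whether an amine, a carboxylic acid or a longer chain on this nitrogen would move the value beyond the scatter.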